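The compounds below may be only part of what the source reports. "The series", "measured", "known", "first", "only" and "open" are said of these compounds alone.

For the measured compounds named here, compound 1, with the structure `O=S(=O)(c1ccccc1)c1nc2ccccc2nc1Nc1ccccc1`, is the one compound of this small set for which a plain number exists. In a functional assay on A549 cells (Homo sapiens) for cytotoxicity, read by MTT assay, with a stated time of 72 h (on this read-out higher numbers stand for weaker inhibition and lower numbers for stronger inhibition), compound 1 gives 26300 nM. Compound 2, with the structure `O=S(=O)(c1ccccc1)c1nc2ccccc2nc1Nc1ccc(F)cc1`, reaches only a limit of the assay: in this assay compound 2 gives > 50000 nM. Compound 3, with the structure `O=S(=O)(c1ccccc1)c1nc2ccccc2nc1Nc1ccc(C(F)(F)F)cc1`, likewise reaches only a limit, giving in this assay > 50000 nM. So among the three values shown, compound 1 stands as the sole measured number, the other two sitting at the limit of > 50000 nM in this assay, at which 2 of the 3 values shown sit.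

Compound 4, with the structure `O=S(=O)(c1ccc(Br)cc1)c1nc2ccccc2nc1Nc1ccccc1`, differs from compound 1 by bromo in place of hydrogen on an aromatic carbon, on the six-membered aromatic ring of carbon only that carries the sulfonyl, para to a large group. Going by the values given here, no measured step changes this ring; the two steps that exist change the other ring, and each went an at least 1.9-fold higher number from compound 1 to compound 2 (0.27 log units; that floor lies within the scatter) and an at least 1.9-fold higher number from compound 1 to compound 3 (0.27 log units; that floor lies within the scatter). Both reached only a limit, so they show no more than that adding a group on an aromatic carbon did not lower the number. On that slender footing, compound 4 is expected to stay near compound 1 or drift to a somewhat higher number, an estimated step of a 1.3-fold higher number from compound 1 to compound 4 (0.12 log units; within the scatter). The estimate for compound 4 is therefore 35000 nM, within a range from 15000 nM to 80000 nM.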

Compound 4, half-maximal inhibitory concentration: 10800 nM
Estimate against measurement, compound 4: 3.2-fold (0.51 log units) above; measured number outside the range, below it.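

In this assay, for the compounds shown here, the change from phenyl to 4-bromophenyl on the ring that carries the sulfonyl gives a 2.4-fold lower number from compound 1 to compound 4 (0.39 log units; beyond the scatter), which makes it the first step in this set whose size can be read and the first that points toward stronger inhibition. Going by these compounds alone, the earlier steps changed the other ring and ended at limits of the assay, so they could show only that the number did not fall; this result shows that the number can fall when a single bromine replaces a hydrogen on an aromatic carbon, para to a large group. It rests on one pair of compounds, however, and nothing shown here explains why bromo has this effect at this place.

Going by these compounds, it remains open whether a different group at the same place, such as chloro, methoxy, an amine or a carboxylic acid, would lower the number as well, or whether the step is particular to bromo. It is also open whether bromo on the other ring would lower the number or raise it, as the measurements shown include no such compound.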